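The source may report more compounds than this note shows. Statements on the series, on what has been measured and on what is new or still open speak of the compounds shown alone.

Two compounds of the series share one core and differ only in the amino group on the aromatic carbon. Compound 1, `CC(C)CCN(CCC(C)C)c1ccc(C(=O)N2CCc3ccc(OS(N)(=O)=O)cc3C2)cc1`, gives 90.8% in an assay on HEK293 cells for inhibition of Steryl-sulfatase (Homo sapiens), tested at 1 uM; a lower number here means a weaker effect, a higher number a stronger effect of the compound at the concentration tested. Compound 2, `CCN(Cc1ccccn1)c1ccc(C(=O)N2CCc3ccc(OS(N)(=O)=O)cc3C2)cc1`, gives 87.7% in this assay; compound 2 stands at the bottom of the two numbers shown, but only by a number 3.1 percentage points lower from compound 1 to compound 2 (within the scatter), which lies within the scatter. The next compound, compound 3, `NS(=O)(=O)Oc1ccc2c(c1)CN(C(=O)c1ccc(N3CCCCC3)cc1)CC2`, differs from compound 2 in one place: piperidin-1-yl in place of ethyl((pyridin-2-yl)methyl)amino on an aromatic carbon. Among the measured compounds shown here, the only step that bears on this change is the earlier exchange of the whole amino group, which gave a number 3.1 percentage points lower from compound 1 to compound 2 (within the scatter), a shift within the scatter. A step in this assay beyond the scatter is therefore not expected for compound 3, in either direction, because a number 3.1 percentage points lower from compound 1 to compound 2 (within the scatter). Compound 3 is expected to give 85%, between 70% and 95%. That is an expected a number 2.7 percentage points lower from compound 2 to compound 3 (within the scatter), within the scatter.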

Compound 3, a percentage reported as inhibition, at one concentration (the size of the read-out at that concentration, not a potency): 38.3%
The estimate for compound 3 lay 46.7 percentage points above the measured number; measured number outside the range, below it.
By their numbers in this assay, from the lowest: compound 3; then compounds 2 and 1 (each within the scatter of the next).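

At this position, on an aromatic carbon para to a large group, the amino group is not freely exchangeable in this assay: piperidin-1-yl in place of ethyl((pyridin-2-yl)methyl)amino gives a number 49.4 percentage points lower from compound 2 to compound 3 (beyond the scatter), and piperidin-1-yl in place of diisopentylamino gives a number 52.5 percentage points lower from compound 1 to compound 3 (beyond the scatter). The earlier exchange between the two acyclic amino groups suggested a tolerant position, but that tolerance does not extend to piperidin-1-yl, so the group's identity matters here. Nothing available accounts for the loss.

Open, as far as these compounds go, is whether the loss follows the smaller size of piperidin-1-yl or the ring that joins the nitrogen substituents. A diethylamino group, a small acyclic amine, and a 4-benzylpiperidin-1-yl group, a larger one that keeps the ring, would separate the two readings.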